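Adding a Benzyloxy Group to Compound 1

The source may report more compounds than this note shows. Statements on the series, on what has been measured and on what is new or still open speak of the compounds shown alone.

Measured compounds:
compound 1 `Cn1c(Cn2c(-c3ccccc3)nc3ccccc32)n[nH]c1=S`: 5%
compound 2 `CNC(=S)NNC(=O)Cn1c(-c2ccc(OC)c(OC)c2)nc2cc(Cl)c(Cl)cc21`: 26%

Of the compounds shown here, two have been measured in a functional assay for inhibition, tested at 0.1 mM; on this read-out lower numbers stand for less inhibition and higher numbers for more inhibition at the one concentration tested (going by the name of the read-out). Compound 1 stands lowest of the two numbers, with 5%. Its nearest neighbour is compound 2, which gives 26%, a number higher by an amount beyond the usual scatter. For the measured compounds named here, the two compounds share no single-point relation, so only their two values can be compared, and no step between them is known.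

Compound 3 `Cn1c(Cn2c(-c3ccc(OCc4ccccc4)cc3)nc3ccccc32)n[nH]c1=S` is not yet measured. It differs from compound 1 in one place: benzyloxy in place of hydrogen on an aromatic carbon. The new group sits on an aromatic carbon of a six-membered aromatic ring of carbon only, para to a large group.

Going by the values given here, with only two measured compounds and no step between them, nothing in the data shows what a change of this kind does. Compound 1 is near the floor of this read-out, so a fall is hardly possible, and the step from compound 1 to compound 3 is expected to be small, a number 7 percentage points higher from compound 1 to compound 3 (within the scatter), likely within or just beyond the scatter in the upward direction. For compound 3 the estimate is 12%, in a range from 0% to 35%.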

Compound 3, a percentage reported as inhibition, at one concentration (the size of the read-out at that concentration, not a potency): 5%
Compound 3: middle estimate off by 7 percentage points, on the high side, within the range that was stated.
By their numbers in this assay, from the lowest: compounds 1 and 3 (each within the scatter of the next); then compound 2.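

In this assay, benzyloxy in place of hydrogen on an aromatic carbon, para to a large group, gives no change at the digits printed from compound 1 to compound 3 (within the scatter). For the compounds shown here, this is the first step in the set that can be read at a single place, and it shows that adding this group, with its own six-membered aromatic ring, at this position brings no measurable gain in inhibition at the one concentration tested. Nothing at hand bears on why this group behaves as it does here.

Compound 1 and compound 3 both stand at the low end of the read-out, so the step says little about whether any other group at this position could raise the number, and a smaller amine or a carboxylic acid in the same place remains an open case. The higher number of compound 2, which differs from both in more than one place, also cannot be traced to any single feature of its structure.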